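The source may report more compounds than this note shows. Statements on the series, on what has been measured and on what is new or still open speak of the compounds shown alone.

Working notes on the series.

Compound 2 `O[C@H]1CO[C@H](COCc2ccccc2)[C@@H](OCc2ccccc2)[C@@H]1OCc1ccccc1` carries a hydroxy group on the ring and in a functional assay on HOS cells (Homo sapiens) for antiproliferative activity, read by sulforhodamine B assay (on this read-out higher numbers stand for weaker inhibition of growth and lower numbers for stronger inhibition of growth), compound 2 gives 37900 nM, the highest number among the three measured compounds. Compound 1 `c1ccc(COC[C@H]2OCC[C@@H](OCc3ccccc3)[C@@H]2OCc2ccccc2)cc1` lacks that hydroxy group, and in this assay compound 1 gives 22200 nM; the step is a 1.7-fold higher number from compound 1 to compound 2 (0.23 log units; within the scatter). Compound 3 `CC(=O)O[C@@H]1[C@@H](OCc2ccccc2)[C@H](OCc2ccccc2)[C@@H](COCc2ccccc2)O[C@H]1C` carries an acetate and a methyl group on the ring, and in this assay compound 3 gives 8800 nM; compound 3 differs from compound 2 in more than one place, so its number only shows that the series can reach lower values.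

Compound 4 `CC[C@@H]1O[C@H](COCc2ccccc2)[C@@H](OCc2ccccc2)[C@H](OCc2ccccc2)[C@H]1O` is not yet measured. The change from compound 2 is ethyl in place of hydrogen on a saturated ring carbon, placed on a saturated ring carbon next to the ring oxygen. Within the data shown here, no measured step covers an alkyl group entering at this position; the only step known, a 1.7-fold higher number from compound 1 to compound 2 (0.23 log units; within the scatter), concerns a hydroxy group and lies within the scatter. With nothing pointing strongly either way, the step to compound 4 is expected to be a 1.5-fold lower number from compound 2 to compound 4 (0.16 log units; within the scatter), and the estimate for compound 4 in this assay is 26000 nM, within 8000 nM to 80000 nM.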

Compound 4, concentration for 50% growth inhibition: 34200 nM
Estimate against measurement, compound 4: 1.3-fold (0.12 log units) below, and the stated range covers the measured number.
By their numbers in this assay, from the lowest: compound 3; then compounds 1, 4 and 2 (each within the scatter of the next).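

In this assay, ethyl in place of hydrogen on this saturated ring carbon, next to the ring oxygen, gives a 1.1-fold lower number from compound 2 to compound 4 (0.04 log units; within the scatter), so the read-out does not separate compound 4 from compound 2. Among these compounds, the position therefore accepts an alkyl group of this size with no step beyond the scatter, which the hydroxy step from the earlier compounds could not show. No evidence at hand bears on this result.

Going by these compounds, whether a longer chain, an amine or a carboxylic acid at this position would give a step beyond the scatter remains open. Among the compounds shown here, also open is how much of the number for compound 3, 8800 nM, belongs to its acetate and how much to its methyl group, as no single-place step separates the two.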